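A Furan Swap on the Benzyl Arm of Compound 2

The compounds below may be only part of what the source reports. "The series", "measured", "known", "first", "only" and "open" are said of these compounds alone.

Of the compounds shown here, three sharing one core have been measured in a functional assay on MGC-803 cells (Homo sapiens) for antiproliferative activity, read by MTT assay, with a stated time of 72 h; a higher number here means a weaker inhibitor, a lower number a stronger inhibitor. Compound 1 `CCCSc1nc(N/N=C(\C)c2ccc(O)cc2)c2nnn(Cc3ccccc3)c2n1` gives 16700 nM, compound 2 `CCCSc1nc(N/N=C(\C)c2ccccc2O)c2nnn(Cc3ccc(O)cc3)c2n1` gives 7680 nM, and compound 3 `C#CCSc1nc(N/N=C/c2c(O)ccc3ccccc23)c2nnn(Cc3ccccc3)c2n1` gives 10500 nM. Compound 2 holds the lowest number of the three; its gap to compound 3 lies within the scatter, while compound 1 sits beyond the scatter above it. Compound 4 `CCCSc1nc(N/N=C(\C)c2ccccc2O)c2nnn(Cc3ccco3)c2n1` has not yet been measured. It differs from compound 2 by furan-2-yl in place of 4-hydroxyphenyl on a saturated chain carbon bound to an aromatic nitrogen, that is, 4-hydroxybenzyl becomes (furan-2-yl)methyl. Among the measured compounds shown here, no measured pair shows this change, so a step of the expected size a 1.3-fold higher number from compound 2 to compound 4 (0.11 log units; within the scatter) is estimated here, without a direction beyond the scatter. Compound 4 is expected to give 10000 nM in this assay, within a range from 4000 nM to 25000 nM.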

Compound 4, half-maximal inhibitory concentration: 4760 nM
Compound 4: middle estimate off by 2.1-fold (0.32 log units), on the high side, within the range that was stated.
By their numbers in this assay, from the lowest: compounds 4, 2, 3 and 1 (each within the scatter of the next, the first and the last beyond it).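

Replacing 4-hydroxybenzyl with (furan-2-yl)methyl gives a 1.6-fold lower number from compound 2 to compound 4 (0.21 log units; within the scatter) in this assay. On this saturated chain carbon, then, a six-membered carbon ring bearing a hydrogen-bond donor can give way to a five-membered aromatic ring with no donor, while the number stays within the scatter of compound 2. No evidence bears on what lies behind this result. The compounds shown leave open whether a thiophen-2-yl or a saturated tetrahydrofuran-2-yl group in this place would keep the number in the same range.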